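A few compounds are considered here, and "the series" means these few. Any claim that something is new, unique, unknown or untested is made for them only; others in the source may bear on it.

In a functional assay on NCI-H520 cells (Homo sapiens) for cytotoxicity (a lower number here means a stronger inhibitor of growth, a higher number a weaker inhibitor of growth), three compounds on a shared core have been measured. Compound 1 `COc1ccc(C2=C(c3ccc(SC)cc3)CC3CCCN3C2=O)cc1O` gives 6000 nM, compound 2 `COc1ccc(C2=C(c3ccc(SC)cc3)CC3CCCN3C2=O)cc1Br` gives 700 nM, and compound 3 `CSc1ccc(C2=C(c3ccc(C)c(C)c3)C(=O)N3CCCC3C2)cc1` gives 300 nM, the lowest of the three numbers. Compound 4 `CSc1ccc(C2=C(c3ccc(O)c(O)c3)C(=O)N3CCCC3C2)cc1` carries 3,4-dihydroxyphenyl in place of 3,4-dimethylphenyl on a double-bonded ring carbon.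

The measured steps at that same carbon offer the closest guide. Putting 3,4-dimethylphenyl in place of 3-hydroxy-4-methoxyphenyl gave a 20-fold lower number from compound 1 to compound 3 (1.30 log units; beyond the scatter), a large step, while bromo in place of hydroxy gave an 8.6-fold lower number from compound 1 to compound 2 (0.93 log units; beyond the scatter), a modest one. Replacing 3-bromo-4-methoxyphenyl with 3,4-dimethylphenyl gave a 2.3-fold lower number from compound 2 to compound 3 (0.37 log units; beyond the scatter), also modest. Among these three compounds, only compound 1 bears a hydroxy group, and it has the highest number at 6000 nM. For the measured compounds named here, no measured compound carries 3,4-dihydroxyphenyl, so the size of the new step remains uncertain. A sizeable move towards weaker growth inhibition is expected, close to the reverse of the large step, and the estimated change is a 10-fold higher number from compound 3 to compound 4 (1.00 log units; beyond the scatter). Compound 4 is estimated at 3000 nM, with an expected range from 800 nM to 10000 nM.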

Compound 4, concentration for 50% growth inhibition: 60000 nM
The estimate for compound 4 lay 20-fold (1.30 log units) below the measured number; measured number outside the range, above it.
By their numbers in this assay, from the lowest: compound 3; then compound 2; then compound 1; then compound 4.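

In this assay, 3,4-dihydroxyphenyl in place of 3,4-dimethylphenyl on the double-bonded ring carbon gives a 200-fold higher number from compound 3 to compound 4 (2.30 log units; beyond the scatter) and in place of 3-bromo-4-methoxyphenyl gives an 86-fold higher number from compound 2 to compound 4 (1.93 log units; beyond the scatter), making compound 4 the weakest inhibitor of growth of the four. Until now, the only hydroxy-bearing ring at this position was the 3-hydroxy-4-methoxyphenyl of compound 1, and hydrogen in place of methyl on its oxygen still gives a 10-fold higher number from compound 1 to compound 4 (1.00 log units; beyond the scatter), so the methoxy-to-hydroxy change also raises the number when a hydroxy group is already present. Across these four compounds, the two bearing hydroxy groups on this ring have the two highest numbers, and none goes against that order.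

On these data alone, what a 3,4-dimethoxyphenyl or 3,4-diaminophenyl group would give on this carbon remains open. The compounds and their numbers offer no evidence on why the hydroxy groups have this effect.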